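The source may hold more compounds than are shown below. What is called first, only, known or untested is meant among the compounds shown, and "the series" means these compounds.

Two compounds of this series have numbers in an assay on HEK293 cells for inhibition of N-acylethanolamine-hydrolyzing acid amidase (Rattus norvegicus), read by LC-MS, with a stated time of 30 min; on this read-out lower numbers stand for stronger inhibition and higher numbers for weaker inhibition. Compound 1, `O=C(CCCCCc1cccc(C(F)(F)F)c1)N1CCOC1=O`, gives 58 nM. Compound 2, `O=C1OCCN1C(=O)c1ccc(Oc2ccccc2)cc1`, gives 680 nM, the higher of the two numbers, and its gap to compound 1 lies beyond the scatter. Compound 3, `O=C1OCCN1C(=O)c1ccc(Oc2cccc(Cl)c2)cc1`, is not yet measured; it differs from compound 2 by chloro in place of hydrogen on an aromatic carbon. Going by the values given here, no step of this kind exists among the measured compounds, so the size of the change is open. For compound 3 a modest decrease is expected, a 2.3-fold lower number from compound 2 to compound 3 (0.36 log units; beyond the scatter), near the edge of the scatter. Compound 3 is therefore estimated at 300 nM, with a range from 100 nM to 1000 nM.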

Compound 3, half-maximal inhibitory concentration: 7740 nM
The estimate for compound 3 lay 26-fold (1.41 log units) below the measured number; the whole stated range lies below it.
By their numbers in this assay, from the lowest: compound 1; then compound 2; then compound 3.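

In this assay, chloro in place of hydrogen on an aromatic carbon, meta to a large group, gives an 11-fold higher number from compound 2 to compound 3 (1.06 log units; beyond the scatter), a large step beyond the scatter. On this read-out, the position is therefore sensitive: a single added chlorine atom on the phenyl of compound 2 weakens inhibition substantially. No available data bear on the reason for this step.

As far as these compounds go, whether fluoro, methyl or methoxy in the same place would give a step of similar size remains open. So does the effect of chloro elsewhere on this ring.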